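The source may hold more compounds than are shown below. What is called first, only, known or untested is meant among the compounds shown, and "the series" means these compounds.

Compound 2 `Cc1ccc(NC(=O)CSc2snnc2-c2ccc(Br)cc2Br)c([N+](=O)[O-])c1` was tested in an ADME assay on MT4 cells (Homo sapiens) for cytotoxicity, read by MTT assay, with a stated time of 5 days (a lower number here means that less compound is tolerated, a higher number that more compound is tolerated), and gives > 229000 nM, which is a limit of the assay rather than a number. Compound 1 `O=C(CSc1snnc1-c1ccc(Br)cc1Br)Nc1ccccc1[N+](=O)[O-]` likewise gives > 235000 nM, also a limit. Compound 3 `Cc1cccc(NC(=O)CSc2snnc2-c2ccc(Br)cc2Br)c1C` gives 241000 nM. Among these three values, compound 2 thus sits at a limit, with one further limit and one plain number of similar magnitude beside it. For the measured compounds named here, both a step that the two limits leave unreadable from compound 1 to compound 2 and a step that the limit leaves unreadable from compound 1 to compound 3 remain unreadable, so no measured step offers a size to lean on. Compound 4 `Cc1ccc(NC(=O)CSc2snnc2-c2ccc(Br)cc2Br)c(Br)c1` differs from compound 2 by bromo in place of nitro on an aromatic carbon. Lacking any readable step, compound 4 is expected to shift by a step that the limit leaves unreadable from compound 2 to compound 4, nothing beyond the scatter. Compound 4 is therefore estimated at 235000 nM, within 120000 nM to 470000 nM, most likely reported again as a limit.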

Compound 4, half-maximal cytotoxic concentration: > 216000 nM
Compound 4 gave a limit, no number (the forecaster's own chance of this, stated with the estimate: 80%); the middle value lies beyond the limit too.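

Compound 4 gives only a limit of the assay, so no new step can be read between compound 4 and compound 1, compound 2 or compound 3. The compounds shown leave open whether bromo in place of nitro changes the result in this assay at all.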